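A few compounds are considered here, and "the series" means these few. Any claim that something is new, unique, unknown or untested is made for them only; others in the source may bear on it.

Measured so far in an ADME assay on HEK293 cells (Homo sapiens) for cytotoxicity, read by CellTiter-Glo and resazurin assay, with a stated time of 72 h; on this read-out lower numbers stand for an effect already at smaller amounts and higher numbers for an effect only at larger amounts of compound:
compound 1 `CC(C)Oc1cccc(-c2ccc(C(=O)N(Cc3cccc(OCCCCCC(=O)O)c3)C(C)C)cc2)c1` — compound 1 gives only the limit > 26000 nM.
compound 2 `CCOC(=O)CCCCCOc1cccc(CN(C(=O)c2ccc(-c3cccnc3)cc2)C(C)C)c1` — compound 2 gives only the limit > 26000 nM.
compound 3 `CCOC(=O)CCCCCOc1cccc(CN(C(=O)c2ccc(-c3cnc(OC)nc3OC)cc2)C(C)C)c1` — compound 3 gives only the limit > 26000 nM.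

None of the three values is a number; each is a limit of this assay. Compound 3 therefore stands nowhere in particular on the numbers shown: it sits at the same limit as compound 1 and compound 2, and nothing separates the three. Going by the values given here, the one measured step, a step that the two limits leave unreadable from compound 2 to compound 3, cannot be read, since both ends are limits. Among the compounds with values here, the only evidence on the series is the limit of > 26000 nM in this assay, at which 3 of the 3 values shown sit.

Compound 4 `CCOC(=O)CCCCCOc1cccc(CN(C(=O)c2ccc(-c3cccc(OC)c3)cc2)C(C)C)c1` is the next compound. Its change from compound 3: 3-methoxyphenyl in place of 2,4-dimethoxypyrimidin-5-yl on an aromatic carbon

Within the data shown here, no measured step bears on this change; the pyridinyl-to-pyrimidinyl exchange in the step to compound 3 left no readable size. Given (the limit of > 26000 nM in this assay, at which 3 of the 3 values shown sit), the expectation for compound 4 is no step beyond the scatter, that is a step that the limit leaves unreadable from compound 3 to compound 4, with the measurement most likely again ending at the limit. Compound 4 is therefore estimated at 40000 nM, with a range of 15000 nM to 120000 nM.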

Compound 4, half-maximal effective concentration: > 21000 nM
Compound 4 ended at the assay's limit; the forecaster's own chance of this, stated with the estimate: 80%; the middle value lies beyond the limit too.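

In this assay compound 4 gives > 21000 nM, which is a limit and not a number. Compound 2 and compound 3 also sit at limits, so neither of their steps to compound 4 can be read. The compounds shown leave open where any of the four would give a numerical half-maximal effective concentration in this assay, and whether exchanging the group on the aromatic carbon shifts it.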